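Swapping the aryl group for ethyl on the ring nitrogen

This account rests on a few compounds, and the source may have more. Where it says the series, first, only, none or still open, it means among the compounds named here.

Compound 1 `CC(C)(C)c1conc1N1C(=O)CSC1c1cccc(C(=O)NCCCCc2ccccc2)c1` reads > 1000 nM (a limit of the assay)
Compound 2 `COc1ccc(F)cc1N1C(=O)CSC1c1cccc(C(=O)NCCCCc2ccccc2)c1` reads 8.8 nM

Within the data shown here, in a functional assay on HOS-TE85 cells (Homo sapiens) for inhibition, read by CCK-8 assay, with a stated time of 72 h (on this read-out lower numbers stand for stronger inhibition and higher numbers for weaker inhibition), compound 2 gives 8.8 nM, and this is the only exact number available for the series. Among the measured compounds shown here, the one other reading belongs to compound 1, and it is a limit: the limit of > 1000 nM in this assay, at which 1 of the 2 values shown sits.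

Compound 3 `CCN1C(=O)CSC1c1cccc(C(=O)NCCCCc2ccccc2)c1` has not yet been measured. It differs from compound 2 at a single place: ethyl in place of 5-fluoro-2-methoxyphenyl on an amide-type nitrogen in a ring.

For the measured compounds named here, one measured step bears on this change, as it concerns the same nitrogen: an at least 110-fold lower number from compound 1 to compound 2 (2.05 log units; beyond the scatter). That large step shows that the number in this assay can move strongly with the group held at this place, although it involved a different pair of groups. A large move towards a higher number is therefore expected on leaving the 5-fluoro-2-methoxyphenyl group of compound 2, and the reading may stop at the limit of this assay. The expected change is a 68-fold higher number from compound 2 to compound 3 (1.83 log units; beyond the scatter). The estimate for compound 3 is 600 nM, within an expected range from 60 nM to 5000 nM.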

Compound 3, half-maximal inhibitory concentration: > 1000 nM
Compound 3 ended at the assay's limit; the forecaster's own chance of this, stated with the estimate: 45%; middle value at least 1.6-fold (0.22 log units) away from the limit.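

Replacing 5-fluoro-2-methoxyphenyl with ethyl on this amide-type nitrogen in a ring gives, in this assay, an at least 110-fold higher number from compound 2 to compound 3 (2.05 log units; beyond the scatter). The earlier step had set one aromatic ring against another, whereas this one shows that a group with no ring at this place also leaves the reading at the limit of the assay: the limit of > 1000 nM in this assay, at which 2 of the 3 values shown sit. Compound 1 and compound 3 both stop at this limit, so the step between them cannot be read, and the two groups cannot be ranked.

Of the groups shown at this place, only 5-fluoro-2-methoxyphenyl gives an exact number, and the compounds shown do not separate the contribution of its aromatic ring from that of its methoxy and fluoro groups. As far as these compounds go, how an unsubstituted phenyl, a benzyl group or a longer chain such as n-butyl would read on this nitrogen remains open, as does the true position of compound 1 and compound 3 beyond the limit.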